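This account rests on a few compounds, and the source may have more. Where it says the series, first, only, none or still open, it means among the compounds named here.

Compound 2, `c1ccc2c(-c3cn4ccnc4c(-c4ccc5ncn(C6CCCCC6)c5c4)n3)cccc2c1`, and compound 1, `c1ccc(-c2cn3ccnc3c(-c3ccc4ncn(C5CCCCC5)c4c3)n2)cc1`, share one core and differ only in the aryl group on its aromatic carbon. In a functional assay on K562 cells (Homo sapiens) for inhibition, read by sulforhodamine B assay, with a stated time of 48 h, tested at 10 uM (a lower number here means less inhibition, a higher number more inhibition at the concentration tested (going by the name of the read-out)), compound 1 gives 70.6%, while compound 2 gives 30.9%, which is the lowest of the two numbers in hand. Among the measured compounds shown here, the single step between them, a number 39.7 percentage points lower from compound 1 to compound 2 (beyond the scatter), is therefore the only measured guide.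

Compound 3, `CC(=O)c1ccc(-c2cn3ccnc3c(-c3ccc4ncn(C5CCCCC5)c4c3)n2)cc1`, is the next in this series. Its change from compound 2 is 4-acetylphenyl in place of naphthalen-1-yl on an aromatic carbon. The step from compound 1 to compound 2 bears on it directly, since the group that leaves compound 2 is the very naphthalen-1-yl whose arrival lowered the read-out by a large amount, and the group that enters is again a single six-membered aromatic ring of carbon only, now carrying an acetyl. For the measured compounds named here, a sizeable rise in this assay is expected, though the acetyl itself has no measured counterpart here, so the estimate is held somewhat below compound 1. The expected step is a number 29.1 percentage points higher from compound 2 to compound 3 (beyond the scatter). Compound 3 is estimated at 60%, within a range from 35% to 85%.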

Compound 3, a percentage reported as inhibition, at one concentration (the size of the read-out at that concentration, not a potency): 9.6%
The estimate for compound 3 lay 50.4 percentage points above the measured number, and the stated range ends above it.
By their numbers in this assay, from the lowest: compound 3; then compound 2; then compound 1.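

In this assay, putting an acetyl in place of hydrogen on the phenyl ring of compound 1 gives a number 61 percentage points lower from compound 1 to compound 3 (beyond the scatter) and is the largest step seen so far, so one substituent on this aryl group can remove most of the read-out without any second fused ring. Exchanging naphthalen-1-yl for 4-acetylphenyl gives a number 21.3 percentage points lower from compound 2 to compound 3 (beyond the scatter) and shows that going back to one six-membered aromatic ring of carbon only does not by itself restore the read-out. Among these compounds, the plain phenyl of compound 1 gives the highest number, and both other aryl groups fall beyond the scatter, though nothing at hand gives a reason for either fall.

The compounds shown leave open whether the loss belongs to the carbonyl itself or to any group at that place on the phenyl ring, which a methyl, a methoxy, an amine or a carboxylic acid there would help to separate. They also leave open whether an acetyl elsewhere on the phenyl ring would lower the read-out as far, and how these single-concentration numbers relate to potency.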